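Notes on the series: from bromo to cyano

The compounds below may be only part of what the source reports. "The series", "measured", "known", "first", "only" and "open" are said of these compounds alone.

In an ADME assay on cells (Macrophage, Mus musculus) for cytotoxicity, read by resazurin assay, with a stated time of 3 days (on this read-out lower numbers stand for stronger inhibition and higher numbers for weaker inhibition), compound 3 (`O=C(Nc1cccc(Br)c1)c1cc(Cl)ccc1O`) gives 5700 nM and compound 1 (`O=C(Nc1cccc(C(F)(F)F)c1)c1cc(Cl)ccc1O`) gives 5900 nM, so the two sit level, with a 1.0-fold lower number from compound 1 to compound 3 (0.01 log units; within the scatter). Compound 2 (`O=C(Nc1cccc(F)c1)c1cc(Cl)ccc1O`) gives 15000 nM, and a 2.6-fold lower number from compound 2 to compound 3 (0.42 log units; beyond the scatter). Compound 4 (`N#Cc1cccc(NC(=O)c2cc(Cl)ccc2O)c1`) carries cyano in place of bromo on an aromatic carbon, meta to a large group. For the measured compounds named here, no measured step involves cyano. The closest guides are the swaps at this same place, which stayed small, with a 2.5-fold higher number from compound 1 to compound 2 (0.41 log units; beyond the scatter) as well as the two steps above. A modest move towards a higher number is therefore expected in this assay. The expected step is a 1.6-fold higher number from compound 3 to compound 4 (0.20 log units; within the scatter). For compound 4 the estimated value is 9000 nM, with an expected range of 4000 nM to 20000 nM.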

Compound 4, half-maximal inhibitory concentration: 10000 nM
The estimate for compound 4 lay 1.1-fold (0.05 log units) below the measured number, and the stated range covers the measured number.
By their numbers in this assay, from the lowest: compounds 3, 1, 4 and 2 (each within the scatter of the next, the first and the last beyond it).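

In this assay cyano on this aromatic carbon cannot be told apart from any of the three earlier groups, with a 1.8-fold higher number from compound 3 to compound 4 (0.24 log units; within the scatter) and a 1.5-fold lower number from compound 2 to compound 4 (0.18 log units; within the scatter) and a 1.7-fold higher number from compound 1 to compound 4 (0.23 log units; within the scatter) as its steps. So the one group here with a triple bond and a hydrogen-bond acceptor gives no step beyond the scatter, and compound 4 falls within the scatter of both ends of the gap that separates compound 2 from compound 3. Nothing at hand explains these steps. Still open, from the compounds shown here alone, is whether an amine or a carboxylic acid on this carbon would give a step beyond the scatter from compound 4.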